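The compounds below may be only part of what the source reports. "The series", "measured", "known", "first", "only" and "open" are said of these compounds alone.

Of the compounds shown here, two from this series have been measured in an assay on cells for inhibition of Voltage-gated L-type calcium channel (Rattus norvegicus), read by fluorescence and calcium flux, with stated times of 30 min and 2 min; on this read-out higher numbers stand for weaker inhibition and lower numbers for stronger inhibition. Compound 1 `COC(=O)C1=C(C)NC(C)=C(C(=O)OC)C1c1cccc(OCC(=O)N2CCCC2)c1` gives 3600 nM in this assay, and compound 2 `COC(=O)C1=C(C)NC(C)=C(C(=O)OC)C1c1ccc(OCC(=O)N2CCN(C)CC2)c(OC)c1` gives 9100 nM, the higher of the two numbers; the gap between them lies beyond the usual scatter of repeated measurements. Compound 3 `COC(=O)C1=C(C)NC(C)=C(C(=O)OC)C1c1ccc(OCC(=O)N2CCCC2)c(OC)c1` has not yet been measured. It differs from compound 2 in one place: pyrrolidin-1-yl in place of 4-methylpiperazin-1-yl on a carbonyl carbon. Among the measured compounds shown here, no measured pair shows this exchange on its own, so no step for it is known. For the measured compounds named here, compound 1 also carries pyrrolidin-1-yl on the carbonyl carbon, but it differs from compound 2 in further respects, so the two values show only that this group can go with a lower number. The step from compound 2 to compound 3 is expected to be a modest lowering, a 1.8-fold lower number from compound 2 to compound 3 (0.26 log units; within the scatter). Compound 3 is therefore estimated at 5000 nM, within a range from 2000 nM to 12000 nM.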

Compound 3, half-maximal inhibitory concentration: 5600 nM
Estimate against measurement, compound 3: 1.1-fold (0.05 log units) below, and the stated range covers the measured number.
By their numbers in this assay, from the lowest: compounds 1, 3 and 2 (each within the scatter of the next, the first and the last beyond it).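

In this assay, the exchange on the carbonyl carbon now has a size of its own, measured with the rest of the molecule unchanged: pyrrolidin-1-yl in place of 4-methylpiperazin-1-yl gives a 1.6-fold lower number from compound 2 to compound 3 (0.21 log units; within the scatter) and nothing else differs. This step lies within the usual scatter, so the five-membered ring and the six-membered ring cannot be told apart at this position in this assay. No measurement at hand bears on the reason for this result.

On these data alone, whether another group on this carbonyl carbon, such as piperidin-1-yl, morpholin-4-yl or an open-chain dimethylamino group, would move the number beyond the scatter stays open. So does whether the same exchange gives a similar step when another part of the molecule is different.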